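The source may report more compounds than this note shows. Statements on the series, on what has been measured and on what is new or still open speak of the compounds shown alone.

Among the compounds with values here, compound 1 `O=C(O)CCc1ccc2[nH]c(-c3ccccc3F)cc2c1` gives 1210 nM in a functional assay on CHO cells for agonist activity at Free fatty acid receptor 1 (Homo sapiens), read by a luciferase reporter, with a stated time of 24 h (on this read-out higher numbers stand for an effect only at larger amounts of compound and lower numbers for an effect already at smaller amounts), and compound 2 `Cc1ccccc1-c1cc2cc(CCC(=O)O)ccc2[nH]1` gives 447 nM, the lower of the two numbers; the only step, a 2.7-fold lower number from compound 1 to compound 2 (0.43 log units; beyond the scatter), is modest but beyond the scatter. Compound 3 `Cc1ncccc1-c1cc2cc(CCC(=O)O)ccc2[nH]1` carries 2-methylpyridin-3-yl in place of 2-methylphenyl on an aromatic carbon. Within the data shown here, no measured step touches this change, since the single known step concerns fluoro against methyl and not a ring nitrogen, so the expectation for compound 3 rests on compound 2 alone. Compound 3 is expected near 600 nM, within 200 nM to 2000 nM. The expected step of a 1.3-fold higher number from compound 2 to compound 3 (0.13 log units; within the scatter) is no more than scatter, with wide uncertainty.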

Compound 3, half-maximal effective concentration: > 25 nM
Compound 3: no number, only a limit; the forecaster's own chance of this, stated with the estimate: 5%; the middle value does not contradict the limit.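

Compound 3 gives only a limit, not a number: the limit of > 25 nM in this assay, at which 1 of the 3 values shown sits. The steps from compound 1 and compound 2 to compound 3 cannot be read. Still open, going by these compounds, is how 2-methylpyridin-3-yl compares with 2-methylphenyl on the shared core.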